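A few compounds are considered here, and "the series" means these few. Any claim that something is new, unique, unknown or untested is made for them only; others in the source may bear on it.

Compounds measured:
- compound 1, `COc1ccc(-c2cnc(NC(=O)c3ccccn3)n2C)cc1`: > 100000 nM
- compound 2, `COc1ccc(-c2cnc(NC(=O)c3ccco3)n2C)cc1`: > 100000 nM
- compound 3, `COc1ccc(-c2cnc(NC(=O)c3ccccc3OC)n2C)cc1`: > 100000 nM

In a toxicity assay on THP-1 cells (Homo sapiens) for inhibition (a higher number here means that more compound is tolerated, a lower number that less compound is tolerated), compound 3 stands only at a limit of the assay, > 100000 nM, not at a number. Compound 1 likewise reaches only the limit, > 100000 nM. Compound 2 also gives only the limit, > 100000 nM. Among the measured compounds shown here, because all three sit at the same limit, (the limit of > 100000 nM in this assay, at which 3 of the 3 values shown sit), none of the measured steps can be read: a step that the two limits leave unreadable from compound 1 to compound 2, a step that the two limits leave unreadable from compound 1 to compound 3 and a step that the two limits leave unreadable from compound 2 to compound 3 each stay hidden between two limits.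

Compound 4, `COc1ccc(C(=O)Nc2ncc(-c3ccc(OC)cc3)n2C)cc1`, has not yet been measured in this assay. It differs from compound 3 in one place, 4-methoxyphenyl in place of 2-methoxyphenyl on a carbonyl carbon: 2-methoxyphenyl leaves and 4-methoxyphenyl enters on the carbonyl carbon whose other neighbour is an amide-type nitrogen. For the measured compounds named here, no measured step bears on this exchange, and the three measured compounds show nothing but the limit.

Compound 4 is therefore expected to remain at the limit as well, with an estimated 150000 nM spanning 100000 nM to 400000 nM. The estimated step from compound 3 is a step that the limit leaves unreadable from compound 3 to compound 4, which is expected to be no readable change.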

Compound 4, half-maximal cytotoxic concentration: > 100000 nM
Compound 4: no number, only a limit; the forecaster's own chance of this, stated with the estimate: 85%; the middle value lies beyond the limit too.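

In this assay compound 4 also reaches only a limit, > 100000 nM. No step from compound 1, compound 2 or compound 3 to compound 4 can be read, because all of them rest at one limit: the limit of > 100000 nM in this assay, at which 4 of the 4 values shown sit.

The compounds shown leave open whether any exchange on the carbonyl carbon changes the concentration tolerated in this assay.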